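This account rests on a few compounds, and the source may have more. Where it says the series, first, only, none or still open, it means among the compounds named here.

In a functional assay on MCF7 cells (Homo sapiens) for antiproliferative activity, read by MTT assay, with a stated time of 72 h (a higher number here means a weaker inhibitor, a lower number a stronger inhibitor), compound 2 `CCn1c(C(=O)NCc2ccc(OC)cc2)ccc1C(CC)(CC)c1ccc(C#CC(O)(CC)CC)c(C)c1` gives > 50000 nM, which is a limit and not a number. Compound 1 `CCn1c(C(=O)NCCC(=O)OC)ccc1C(CC)(CC)c1ccc(C#CC(O)(CC)CC)c(C)c1` gives > 50000 nM, also a limit. Compound 3 `CCCCC(=O)c1ccc(C(CC)(CC)c2ccc(C#CC(O)(CC)CC)c(C)c2)n1CC` gives > 50000 nM, again a limit. All the data so far stand at the limit of > 50000 nM in this assay, at which 3 of the 3 values shown sit. Compound 4 `CCn1c(C(=O)N[C@H](C(=O)O)C(C)C)ccc1C(CC)(CC)c1ccc(C#CC(O)(CC)CC)c(C)c1` carries 1-carboxy-2-methylpropyl in place of 4-methoxybenzyl on an amide-type nitrogen. The measured steps closest to this change are a step that the two limits leave unreadable from compound 1 to compound 2 and a step that the two limits leave unreadable from compound 2 to compound 3, and neither has a size that can be read. The step that the two limits leave unreadable from compound 1 to compound 3 is no more informative. The expected outcome is therefore a step that the limit leaves unreadable from compound 2 to compound 4, with no step beyond the scatter in either direction. For compound 4 the estimate is 60000 nM, with an expected range of 25000 nM to 100000 nM.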

Compound 4, half-maximal inhibitory concentration: 13000 nM
For compound 4 the middle estimate is 4.6-fold (0.66 log units) above the measured one; measured number outside the range, below it.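

In this assay, for the compounds shown here, a change on the amide-type nitrogen gives a readable step for the first time: 1-carboxy-2-methylpropyl in place of 4-methoxybenzyl gives an at least 3.8-fold lower number from compound 2 to compound 4 (0.58 log units; beyond the scatter), and in place of 2-(methoxycarbonyl)ethyl it gives an at least 3.8-fold lower number from compound 1 to compound 4 (0.58 log units; beyond the scatter). On the carbonyl carbon, (1-carboxy-2-methylpropyl)amino in place of butyl gives an at least 3.8-fold lower number from compound 3 to compound 4 (0.58 log units; beyond the scatter). The steps among the earlier compounds cannot be read, and these new steps are themselves bounded by a limit: the limit of > 50000 nM in this assay, at which 3 of the 4 values shown sit.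

Going by these compounds, whether these steps belong to the carboxy group or to the branched chain stays open. So does what an amine in place of the carboxy group would give on the same chain.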